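A few compounds are considered here, and "the series" means these few. Any claim that something is new, unique, unknown or untested is made for them only; others in the source may bear on it.

In an assay on membranes from HEK293 cells for displacement of a labelled ligand from adenosine receptor A2b (Homo sapiens), read by scintillation counting, with a stated time of 30 min, tested at 1 uM (on this read-out lower numbers stand for less inhibition and higher numbers for more inhibition at the one concentration tested (going by the name of the read-out)), compound 1 `CC1=C(C(N)=O)C(c2ccsc2)NC(=O)N1` gives 1%, compound 2 `CC1=C(C(=O)SC(C)C)C(c2ccsc2)NC(=O)N1` gives 14%, and compound 3 `CCC(CC)OC(=O)C1=C(C)NC(=O)NC1c1ccco1` gives 35%, the highest of the three numbers, its gaps to both other compounds being beyond the scatter. For the measured compounds named here, the only measured step, a number 13 percentage points higher from compound 1 to compound 2 (beyond the scatter), concerns the group on a carbonyl carbon and not the five-membered aromatic ring. Compound 4 `CCC(CC)OC(=O)C1=C(C)NC(=O)NC1c1ccsc1` differs from compound 3 by thiophen-3-yl in place of furan-2-yl on a saturated ring carbon. Going by the values given here, no measured step bears on this change; compounds 1 and 2 carry thiophen-3-yl, yet they also differ from compound 3 at the carbonyl carbon, so their values show no clean comparison. The expected step is therefore a number 5 percentage points lower from compound 3 to compound 4 (within the scatter), not beyond the scatter. The estimate for compound 4 is 30%, ranging from 15% to 48%.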

Compound 4, a percentage reported as inhibition, at one concentration (the size of the read-out at that concentration, not a potency): 26%
Estimate against measurement, compound 4: 4 percentage points above; low and high end bracket the measured number.
By their numbers in this assay, from the lowest: compound 1; then compound 2; then compounds 4 and 3 (each within the scatter of the next).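

In this assay, thiophen-3-yl in place of furan-2-yl on a saturated ring carbon comes to a number 9 percentage points lower from compound 3 to compound 4 (within the scatter), so the two rings are not told apart at this position. With thiophen-3-yl held fixed, the group on the carbonyl carbon can now be read: (pentan-3-yl)oxy in place of isopropylsulfanyl gives a number 12 percentage points higher from compound 2 to compound 4 (beyond the scatter), and in place of amino it gives a number 25 percentage points higher from compound 1 to compound 4 (beyond the scatter). Going by these compounds, whether a phenyl ring on that ring carbon, or a longer chain in place of (pentan-3-yl)oxy, would read differently stays open. Nothing available here explains these numbers.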